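Fluoro, chloro and a methoxy on a shared diphenyl core

This account rests on a few compounds, and the source may have more. Where it says the series, first, only, none or still open, it means among the compounds named here.

Compound 1: `Nc1ncc(-c2ccccc2)c(-c2ccccc2)n1` gives 32% in an assay on CHO cells for displacement of a labelled ligand from adenosine receptor A1 (Homo sapiens), read by scintillation counting, with a stated time of 1 h, tested at 1 uM; a lower number here means less inhibition, a higher number more inhibition at the concentration tested (going by the name of the read-out).
Compound 2: `Nc1ncc(-c2ccc(F)cc2)c(-c2ccccc2)n1` reaches the limit of the assay, > 80%, a limit and not a number.
Compound 3: `Nc1ncc(-c2cccc(Cl)c2)c(-c2ccccc2)n1` likewise sits at the limit, > 80%.

Going by the values given here, compound 1 is the one compound with a plain number; the two others are at a limit of the assay, which is the point made by the limit of > 80% in this assay, at which 2 of the 3 values shown sit. The compound not yet measured is compound 4, `COc1ccccc1-c1cnc(N)nc1-c1ccccc1`. Its change from compound 1 is methoxy in place of hydrogen on an aromatic carbon.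

Among the compounds with values here, two measured steps bear on this one, both starting from compound 1 and both adding a single small substituent to the same phenyl ring: a number at least 48 percentage points higher from compound 1 to compound 2 (beyond the scatter) and a number at least 48 percentage points higher from compound 1 to compound 3 (beyond the scatter). Both were large and went upward. The methoxy of compound 4 is a different group, carries an oxygen, and sits ortho to a large group, so the two steps are a guide rather than a match.

An upward step beyond the scatter is nevertheless expected, a number 23 percentage points higher from compound 1 to compound 4 (beyond the scatter), though smaller and less certain than the two measured ones. For compound 4 the estimated inhibition is 55%, with a range from 25% to 85%.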

Compound 4, a percentage reported as inhibition, at one concentration (the size of the read-out at that concentration, not a potency): 20%
Compound 4: the middle estimate sits 35 percentage points above what was measured, outside the stated range (below it).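

The methoxy ortho to a large group gives a number 12 percentage points lower from compound 1 to compound 4 (beyond the scatter), so in this assay adding a group to this ring does not by itself raise the number. The fluoro and chloro steps went the other way, a number at least 48 percentage points higher from compound 1 to compound 2 (beyond the scatter) and a number at least 48 percentage points higher from compound 1 to compound 3 (beyond the scatter), which means the direction of change is not shared by all three additions to compound 1, although the entering group and its place are not separated by these compounds. The step to compound 4 is also the only one here that joins two plain numbers, so it is the only one whose full size is known: the limit of > 80% in this assay, at which 2 of the 4 values shown sit.

The compounds shown leave open whether a methoxy elsewhere on this ring would behave like the fluoro and chloro, and whether a fluoro or chloro ortho to a large group would lower the number as the methoxy does. Also open, from the compounds shown here alone, is how an amine, a hydroxyl or a carboxylic acid ortho to a large group would read in this assay, and so whether the drop belongs to the methoxy alone.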